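Changing the Aryl Group on a Sulfonamide Nitrogen

The compounds below may be only part of what the source reports. "The series", "measured", "known", "first", "only" and "open" are said of these compounds alone.

Compound 1 `COc1ccc(NS(=O)(=O)c2ccc(N3CCNC3=O)cc2)cc1`: 800 nM in a functional assay on HT-29 cells (Homo sapiens) for antiproliferative activity, read by sulforhodamine B assay, with a stated time of 48 h; a lower number here means a stronger inhibitor, a higher number a weaker inhibitor
Compound 2 `CC(C)Cc1ccc(NS(=O)(=O)c2ccc(N3CCNC3=O)cc2)cc1`: a limit, > 1000 nM
Compound 3 `COc1ccccc1NS(=O)(=O)c1ccc(N2CCNC2=O)cc1`: 550 nM

Compound 3 gives the lower of the two numbers shown, but the gap a 1.5-fold lower number from compound 1 to compound 3 (0.16 log units; within the scatter) is within the scatter, so the two cannot be told apart. Compound 4 `O=C1NCCN1c1ccc(S(=O)(=O)Nc2ccc(I)cc2)cc1` is not yet measured; it differs from compound 3 in one place: 4-iodophenyl in place of 2-methoxyphenyl on a sulfonamide nitrogen. Within the data shown here, two measured steps bear on this change. Moving the methoxy group gave a 1.5-fold lower number from compound 1 to compound 3 (0.16 log units; within the scatter). Replacing methoxy with isobutyl gave an at least 1.2-fold higher number from compound 1 to compound 2 (0.09 log units; that floor lies within the scatter), a floor set by the limit of > 1000 nM in this assay, at which 1 of the 3 values shown sits. Removing the acceptor and adding a large halogen resembles the second step more than the first, so in this assay a small rise or no change beyond the scatter is expected. Compound 4 is estimated to give 750 nM, between 300 nM and 1800 nM. That expected change is a 1.4-fold higher number from compound 3 to compound 4 (0.13 log units; within the scatter).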

Compound 4, half-maximal inhibitory concentration: 650 nM
Compound 4: the middle estimate sits 1.2-fold (0.06 log units) above what was measured, and the stated range covers the measured number.
By their numbers in this assay, from the lowest: compounds 3, 4 and 1 (each within the scatter of the next). At a limit, above all of these: compound 2.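

In this assay, 4-iodophenyl in place of 2-methoxyphenyl on a sulfonamide nitrogen gives a 1.2-fold higher number from compound 3 to compound 4 (0.07 log units; within the scatter) and iodo in place of methoxy gives a 1.2-fold lower number from compound 1 to compound 4 (0.09 log units; within the scatter) so an aryl group with no hydrogen-bond acceptor sits level with both methoxy compounds. Compound 2 stands at a limit, and iodo in place of isobutyl gives an at least 1.5-fold lower number from compound 2 to compound 4 (0.18 log units; that floor lies within the scatter) so only a floor can be read, not the true size of this step: the limit of > 1000 nM in this assay, at which 1 of the 4 values shown sits.

No change at this position has yet moved the number beyond the scatter. Going by these compounds, whether an amine or a carboxylic acid on this aryl group would do so stays open.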